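This account rests on a few compounds, and the source may have more. Where it says the series, first, only, none or still open, it means among the compounds named here.

Measured so far:
compound 1 `COc1ccc(-c2nnc(SC/C(=N/O)c3ccccc3)n2-c2ccccc2)cc1OC`, 61%
compound 2 `CCn1c(SCC(=O)c2ccccc2)nnc1-c1cc(OC)c(OC)c(OC)c1`, 41%
compound 3 `CCn1c(SC/C(=N/O)c2ccccc2)nnc1-c1cc(OC)c(OC)c(OC)c1`, 67%

In a functional assay on the whole organism (strain albino) for inhibition, with Rattus norvegicus as the target, read by paw edema, with a stated time of 2 h, at a dose of 0.28 mmol/kg by the oral route (a higher number here means more inhibition at the dose given (going by the name of the read-out), a lower number less inhibition), compound 3 holds the highest of the three numbers. Compound 1 gives 61%, which lies within the scatter of the value of compound 3. Compound 2 gives 41%, beyond the scatter below compound 3. Within the data shown here, the one step between compounds differing in a single place is a number 26 percentage points higher from compound 2 to compound 3 (beyond the scatter); it concerns the group on the saturated chain carbon bound to the sulfur, not the aromatic ring carrying the methoxy groups, so it does not bear on the change now considered.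

Compound 4 `CCn1c(SC/C(=N/O)c2ccccc2)nnc1-c1ccc(OC)c(OC)c1` differs from compound 3 by hydrogen in place of methoxy on an aromatic carbon. Among the measured compounds shown here, no measured step covers this change. Compound 1 also carries two methoxy groups on that ring and its value sits within the scatter of compound 3, but compound 1 differs from compound 3 in a second place as well, so it is at most a weak pointer. The expected step of a number 5 percentage points lower from compound 3 to compound 4 (within the scatter) is therefore none beyond the scatter. For compound 4 the estimate is 62%, with a range of 48% to 74%.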

Compound 4, a percentage reported as inhibition, in the whole organism at one dose (the size of the read-out at that dose, not a potency): 67%
The estimate for compound 4 lay 5 percentage points below the measured number, within the range that was stated.
By their numbers in this assay, from the lowest: compound 2; then compounds 1, 3 and 4 (each within the scatter of the next).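

In this assay the step reads no change at the digits printed from compound 3 to compound 4 (within the scatter), so on this aromatic carbon, ortho to a methoxy group, the read-out does not separate methoxy from hydrogen at the dose given. Among these compounds, with the ring held the same, the aromatic nitrogen can now be read in a single place for the first time, as a number 6 percentage points higher from compound 1 to compound 4 (within the scatter), and ethyl and phenyl are likewise not separated there. Nothing shown gives a reason for either result.

Open, from the compounds shown here alone, is whether a hydroxy group or a chlorine atom on this aromatic carbon would read the same, and whether the level holds with the remaining methoxy groups also replaced by hydrogen. Equally open, going by these compounds, is whether a longer chain such as butyl on the aromatic nitrogen stays within the same range.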